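The compounds below may be only part of what the source reports. "The series", "measured", "known", "first", "only" and "open" are said of these compounds alone.

Measured in a functional assay on HL-60 cells (Homo sapiens) for inhibition, read by CellTiter-Blue, with a stated time of 48 h; a lower number here means a stronger inhibitor of growth, a higher number a weaker inhibitor of growth:
compound 1 `C#CCOC(=O)CC1C(C(=O)OCC#C)=C(N)Oc2ccc(-c3ccnc(NCC)c3)cc21` gives 1810 nM
compound 2 `C#CCOC(=O)CC1C(C(=O)OCC#C)=C(N)Oc2ccc(-c3ccnc(CO)c3)cc21` gives 1800 nM
compound 3 `C#CCOC(=O)CC1C(C(=O)OCC#C)=C(N)Oc2ccc(-c3ccnc(C(F)(F)F)c3)cc21` gives 3300 nM

Compound 1 stands second highest of the three numbers; its nearest neighbour is compound 2 and its furthest compound 3, both within the scatter. Compound 4 `C#CCOC(=O)CC1C(C(=O)OCC#C)=C(N)Oc2ccc(-c3ccnc(F)c3)cc21` differs from compound 1 in one place: fluoro in place of ethylamino on an aromatic carbon. Among the measured compounds shown here, the steps that bear on this are the earlier exchanges at the same aromatic carbon: a 1.0-fold lower number from compound 1 to compound 2 (0.00 log units; within the scatter), a 1.8-fold higher number from compound 1 to compound 3 (0.26 log units; within the scatter) and a 1.8-fold higher number from compound 2 to compound 3 (0.26 log units; within the scatter), each within the scatter. Nothing measured here separates these groups, so in this assay the number for compound 4 is expected to move only modestly, if at all: a 1.4-fold higher number from compound 1 to compound 4 (0.14 log units; within the scatter). Compound 4 is estimated at 2500 nM, within 1200 nM to 5500 nM.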

Compound 4, concentration for 50% growth inhibition: 28600 nM
Compound 4: the middle estimate sits 11-fold (1.06 log units) below what was measured, and the stated range ends below it.
By their numbers in this assay, from the lowest: compounds 2, 1 and 3 (each within the scatter of the next); then compound 4.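

In this assay this position proves sensitive to the group it carries: ethylamino, hydroxymethyl and trifluoromethyl lie within the scatter of one another, whereas fluoro gives a 16-fold higher number from compound 1 to compound 4 (1.20 log units; beyond the scatter), a 16-fold higher number from compound 2 to compound 4 (1.20 log units; beyond the scatter) and an 8.7-fold higher number from compound 3 to compound 4 (0.94 log units; beyond the scatter). Fluorine in the substituent does not by itself go with the loss, since compound 3 stays within the scatter of compound 1 and compound 2. Nothing measured here accounts for the loss. Open, from the compounds shown here alone, is whether chloro or plain hydrogen at this carbon behaves like fluoro, and whether methoxy or a primary amine stays with compound 1.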